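This account rests on a few compounds, and the source may have more. Where it says the series, first, only, none or still open, it means among the compounds named here.

Compound 1 `CCc1ccc(/C=C/C(=O)N[C@@H]2O[C@H](CO)[C@@H](O)[C@H](O)[C@H]2O)cc1` gives 94.7 nm/s. Compound 2 `C[C@H](CC(=O)N[C@@H]1O[C@H](CO)[C@@H](O)[C@H](O)[C@H]1O)c1ccc(C(C)(C)C)cc1` gives 97.7 nm/s. Compound 3 `COc1cc(/C=C/C(=O)N[C@@H]2O[C@H](CO)[C@@H](O)[C@H](O)[C@H]2O)cc(OC)c1` gives 80 nm/s.

These numbers come from an ADME assay on Caco-2 cells (Homo sapiens) for permeability; a lower number here means that the compound crosses the layer more slowly, a higher number that the compound crosses the layer faster. Compound 1 sits among the three with gaps to compound 2 and to compound 3 that both lie within the usual scatter, so no ordering among them can be claimed. Compound 4 `O=C(/C=C/c1ccc(-c2ccccc2)cc1)N[C@@H]1O[C@H](CO)[C@@H](O)[C@H](O)[C@H]1O` has not yet been measured in this assay; it differs from compound 1 in one place: phenyl in place of ethyl on an aromatic carbon. Among the compounds with values here, no step between measured compounds is available to guide this change. The nearest hint is that compound 3, carrying a different group on the shared core, gave 80 nm/s, close to compound 1. The expected step is therefore small, a 1.1-fold lower number from compound 1 to compound 4 (0.05 log units; within the scatter), within the scatter. Compound 4 is estimated at 85 nm/s, in the range 45 nm/s to 160 nm/s.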

Compound 4, apparent permeability: 80.2 nm/s
The estimate for compound 4 lay 1.1-fold (0.03 log units) above the measured number; the measured number falls inside the stated range.
By their numbers in this assay, from the lowest: compounds 3, 4, 1 and 2 (each within the scatter of the next).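

At this position, on an aromatic carbon para to a large group, this assay now has its first direct comparison: phenyl in place of ethyl gives a 1.2-fold lower number from compound 1 to compound 4 (0.07 log units; within the scatter). Replacing the two carbons of ethyl with the six-membered aromatic ring of phenyl therefore leaves the number within the scatter. No measurement shown explains this result. 

One step cannot show a trend at this position. On these data alone, it remains open whether an amine, a carboxylic acid or a longer chain there would move the number beyond the scatter.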